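Removing the (4-chlorophenyl)carbonyl from compound 3

This account rests on a few compounds, and the source may have more. Where it says the series, first, only, none or still open, it means among the compounds named here.

Compound 3 `COc1cc(/C=C/C(=O)c2cccc(NC(=O)c3ccc(Cl)cc3)c2)ccc1O` gives > 50 ug/mL in a functional assay on U-87MG ATCC cells (Homo sapiens) for inhibition (on this read-out lower numbers stand for stronger inhibition and higher numbers for weaker inhibition), which is a limit and not a number. Compound 2 `COc1cc(/C=C/C(=O)c2cccc(NC(=O)c3cc(Cl)cc(Cl)c3)c2)ccc1O` gives > 50 ug/mL, also a limit. Compound 3 therefore stands at the limit of > 50 ug/mL in this assay, at which 2 of the 3 values shown sit. Only compound 1 `COc1cc(/C=C/C(=O)c2cccc(NC(=O)c3c(Cl)cccc3Cl)c2)ccc1O` has a measured number, 17.8 ug/mL.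

Compound 4 `COc1cc(/C=C/C(=O)c2cccc(N)c2)ccc1O` arises from compound 3 through hydrogen in place of (4-chlorophenyl)carbonyl on a nitrogen on an aromatic ring.

Within the data shown here, three measured steps bear on this change, though only indirectly, since each swaps the aryl group on the carbonyl carbon and none removes the carbonyl group. an at least 2.8-fold higher number from compound 1 to compound 2 (0.44 log units; beyond the scatter) and an at least 2.8-fold higher number from compound 1 to compound 3 (0.44 log units; beyond the scatter) show that the read-out can move with that group. a step that the two limits leave unreadable from compound 2 to compound 3 gives no usable size. Among the measured compounds shown here, no measured step therefore fixes the size of the change expected here. A modest step toward a lower number is expected, with a real chance that the result stays at the limit, as for compound 3 at > 50 ug/mL. The expected change is an at least 1.4-fold lower number from compound 3 to compound 4 (0.15 log units; that floor lies within the scatter). Compound 4 is estimated at 35 ug/mL, with an expected range of 12 ug/mL to 90 ug/mL.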

Compound 4, half-maximal inhibitory concentration: 7.71 ug/mL
For compound 4 the middle estimate is 4.5-fold (0.66 log units) above the measured one; measured number outside the range, below it.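

In this assay, hydrogen in place of (4-chlorophenyl)carbonyl on a nitrogen on an aromatic ring gives an at least 6.4-fold lower number from compound 3 to compound 4 (0.81 log units; beyond the scatter), and hydrogen in place of (3,5-dichlorophenyl)carbonyl gives an at least 6.4-fold lower number from compound 2 to compound 4 (0.81 log units; beyond the scatter). Both steps start from a limit of the assay and not from a number, so only their floors can be read. The step from the one acylated compound with a measured number, hydrogen in place of (2,6-dichlorophenyl)carbonyl, gives a 2.3-fold lower number from compound 1 to compound 4 (0.36 log units; beyond the scatter), so the earlier swaps among aryl groups on the carbonyl carbon gave no hint of what this series now shows: among the compounds shown, compound 4 with its free amine is the strongest, and none of the three carbonyl-bearing groups on that nitrogen improves on hydrogen.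

The compounds shown leave open whether the lower number needs the free amine itself or only the loss of the chlorophenyl ring, and an acetyl or a methyl on that nitrogen would tell these two apart. Also open, as far as these compounds go, is how the read-out responds to a hydroxyl or a carboxylic acid in place of the amine.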